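The source may hold more compounds than are shown below. What is called first, only, known or untested is meant among the compounds shown, and "the series" means these compounds.

Measured in a functional assay on cells (T-cell line, Homo sapiens) for inhibition; a lower number here means a stronger inhibitor, a higher number a weaker inhibitor: compound 1 `COc1ccc(CCCN2CCC(COCc3ccc(Cl)c(Cl)c3)CC2)cc1` gives 200 nM; compound 2 `Clc1ccc(CCCN2CCC(COC(c3ccccc3)c3ccccc3)CC2)cc1` gives 500 nM.

Of these two numbers, compound 2 stands highest. Its nearest neighbour, compound 1, gives a lower number in this assay, and that gap lies beyond the usual scatter of repeated measurements. The two compounds differ in more than one place, so their pair tells nothing about any single change on its own.

Compound 3 `CCCCCCCCCN1CCC(COC(c2ccccc2)c2ccccc2)CC1` departs from compound 2 in one place: hexyl in place of 4-chlorophenyl on a saturated chain carbon, three bonds along the chain from an amine nitrogen in a ring. Among the compounds with values here, no measured pair in this set isolates a change of this kind, so the direction of the step rests on the structural change alone. A hexyl chain carries none of the ring of the 4-chlorophenyl group that leaves, and a modest loss is expected, with the step from a 1.8-fold higher number from compound 2 to compound 3 (0.26 log units; within the scatter) taken as the estimate. Compound 3 is therefore expected to give about 900 nM in this assay, within a range from 200 nM to 4000 nM.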

Compound 3, half-maximal inhibitory concentration: 700 nM
For compound 3 the middle estimate is 1.3-fold (0.11 log units) above the measured one; the range from low to high includes it.
By their numbers in this assay, from the lowest: compound 1; then compounds 2 and 3 (each within the scatter of the next).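

In this assay the change of 4-chlorophenyl to hexyl gives a 1.4-fold higher number from compound 2 to compound 3 (0.15 log units; within the scatter) and so stays inside the scatter. Within the data shown here, this is the first pair in the set that differs in one place, and it shows that at this position, on a saturated chain carbon, three bonds along the chain from an amine nitrogen in a ring, an open hexyl chain cannot be told apart from the ring-bearing 4-chlorophenyl group. Nothing at hand accounts for this result.

Going by these compounds, what remains open is whether the same holds for a shorter chain such as butyl, or for a hexyl chain ending in an amine or a carboxylic acid. The gap between compound 1 and the other two compounds also stays unassigned to any single change, since compound 1 differs from each of them in more than one place.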